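This account rests on a few compounds, and the source may have more. Where it says the series, first, only, none or still open, it means among the compounds named here.

In an ADME assay on RAW264.7 cells (Mus musculus) for cytotoxicity, read by MTT assay, with a stated time of 24 h (on this read-out lower numbers stand for stronger inhibition and higher numbers for weaker inhibition), two compounds sharing one core have been measured so far. Compound 1 (`CCS(=O)(=O)Oc1ccc2c3c(c(=O)oc2c1)CCCCCC3`) gives 21500 nM, and compound 2 (`O=c1oc2cc(OS(=O)(=O)C3CC3)ccc2c2c1CCCCCC2`) gives 10500 nM, the lower of the two numbers. Compound 3 (`O=c1oc2cc(OS(=O)(=O)c3ccccc3)ccc2c2c1CCCCCC2`) has not yet been measured. It differs from compound 2 in one place: phenyl in place of cyclopropyl on a sulfonyl sulfur, with phenyl in place of cyclopropyl on a sulfonyl sulfur.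

For the measured compounds named here, only one measured step bears on this change, since it falls at the same place: a 2.0-fold lower number from compound 1 to compound 2 (0.31 log units; beyond the scatter), with cyclopropyl in place of ethyl on a sulfonyl sulfur. That step is modest, lying just beyond the scatter. Going by the values given here, no measured compound carries phenyl on the sulfonyl sulfur, so this single step offers a guide to the likely size of the change but only a weak one to its direction. A step of similar or smaller size is therefore expected, leaning towards a lower number. The estimated step is a 1.3-fold lower number from compound 2 to compound 3 (0.12 log units; within the scatter). Compound 3 is expected at 8000 nM, with an estimated range of 3000 nM to 20000 nM.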

Compound 3, half-maximal inhibitory concentration: > 100000 nM
Compound 3 ended at the assay's limit; the forecaster's own chance of this, stated with the estimate: 10%; middle value at least 12-fold (1.09 log units) from the limit.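

In this assay compound 3 reads > 100000 nM, which is a limit of the assay and the only such value among the compounds shown: the limit of > 100000 nM in this assay, at which 1 of the 3 values shown sits. Phenyl in place of cyclopropyl brings an at least 9.5-fold higher number from compound 2 to compound 3 (0.97 log units; beyond the scatter) and phenyl in place of ethyl brings an at least 4.6-fold higher number from compound 1 to compound 3 (0.66 log units; beyond the scatter), so the number at this position can rise well past both earlier compounds. For the compounds shown here, the only earlier step, a 2.0-fold lower number from compound 1 to compound 2 (0.31 log units; beyond the scatter), had moved the number down, which shows that the group on a sulfonyl sulfur whose other neighbour is oxygen on an aromatic ring can shift this read-out in either direction and by more than that first step suggested.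

From the compounds shown here alone, how far compound 3 lies past its limit stays open, and with it the true size of both new steps. Also open, going by these compounds, is whether the rise follows from the aromatic ring itself or from the ring's six heavy atoms, which a cyclohexyl group on the same sulfonyl sulfur would separate, and how a pyridyl ring or a methoxy-bearing phenyl would read there.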